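Swapping the Amide Aryl Groups in a Diamide Series

The source may report more compounds than this note shows. Statements on the series, on what has been measured and on what is new or still open speak of the compounds shown alone.

Compound 1 `CN(C)c1ccc(C(=O)N[C@H]2CCC[C@H](NC(=O)c3cccc(Cl)c3)C2)cc1`: 473 nM
Compound 2 `N#Cc1cccc(C(=O)N[C@@H]2CCC[C@H](NC(=O)c3ccccn3)C2)c1`: > 10000 nM
Compound 3 `O=C(N[C@@H]1CCC[C@H](NC(=O)c2ccccn2)C1)c1cccc(Cl)c1`: 1510 nM

In a functional assay on HEK293 cells for antagonist activity at metabotropic glutamate receptor 5 (Homo sapiens), read by FLIPR and calcium flux (on this read-out higher numbers stand for weaker inhibition and lower numbers for stronger inhibition), compound 1 gives 473 nM, the lower of the two numbers reported. Compound 3 gives 1510 nM in this assay. For compound 2 only a limit is reported, > 10000 nM; this is the limit of > 10000 nM in this assay, at which 1 of the 3 values shown sits. Going by the values given here, the one measured step, an at least 6.6-fold lower number from compound 2 to compound 3 (0.82 log units; beyond the scatter), concerns the other amide aryl group.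

Compound 4 `O=C(N[C@H]1CCC[C@H](NC(=O)c2ccccc2F)C1)c1cccc(Cl)c1` differs from compound 1 in the first amide: 2-fluorophenyl in place of 4-(dimethylamino)phenyl on a carbonyl carbon. Among the compounds with values here, no measured pair involves this change, so the step that compound 4 makes cannot be read from the data. Within the data shown here, the only step available, an at least 6.6-fold lower number from compound 2 to compound 3 (0.82 log units; beyond the scatter), shows that an exchange of aryl substituents can move the number beyond the scatter, but it gives no direction for the present change. Compound 4 is therefore expected near compound 1, with a wide range and a slight lean toward a higher number, as a 1.9-fold higher number from compound 1 to compound 4 (0.28 log units; within the scatter). The estimate for compound 4 in this assay is 900 nM, between 300 nM and 3000 nM.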

Compound 4, half-maximal inhibitory concentration: 175 nM
Beside the measured number, compound 4's estimate is 5.1-fold (0.71 log units) above it; measured number outside the range, below it.
By their numbers in this assay, from the lowest: compound 4; then compound 1; then compound 3. At a limit, above all of these: compound 2.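

In this assay, going by these compounds alone, the aryl group on this carbonyl carbon proves able to move the number with the rest of the molecule unchanged: 2-fluorophenyl in place of 4-(dimethylamino)phenyl gives a 2.7-fold lower number from compound 1 to compound 4 (0.43 log units; beyond the scatter), which is the only measured step at this place. The entering group has fewer heavy atoms and no hydrogen-bond acceptor, but this single pair cannot separate those differences from the arrival of the fluorine or the loss of the dimethylamino group. Nothing measured here accounts for the step.

On these data alone, whether a plain phenyl, a 4-fluorophenyl or a 2-chlorophenyl on this carbonyl carbon would give a similar number remains open. So does whether an amine or a carboxylic acid would be tolerated on this ring.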